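A few compounds are considered here, and "the series" means these few. Any claim that something is new, unique, unknown or untested is made for them only; others in the source may bear on it.

In a functional assay on HT-29 cells (Homo sapiens) for inhibition, read by luminescence and CellTiter-Glo, with a stated time of 24 h (a higher number here means that more compound is needed for the effect, a lower number that less compound is needed), compound 1 `CCn1nc(C(=O)N[C@H]2COc3ccccc3N(C)C2=S)nc1Cc1ccccc1` gives 17 nM. Going by the values given here, compound 2 `CN1C(=S)[C@@H](NC(=O)c2nc(Cc3ccccc3)n(CCCF)n2)COc2ccccc21` gives 4760 nM in this assay, the higher of the two numbers, and the only measured step, a 280-fold higher number from compound 1 to compound 2 (2.45 log units; beyond the scatter), sits on the same saturated chain carbon bound to an aromatic nitrogen. Compound 3 `CN1C(=S)[C@@H](NC(=O)c2nc(Cc3ccccc3)n(CC3COC3)n2)COc2ccccc21` changes that chain again: oxetan-3-yl in place of 2-fluoroethyl on a saturated chain carbon bound to an aromatic nitrogen. Among the compounds with values here, no measured step covers an oxetan-3-yl here, and the one step at this site was large, so a sizeable move in either direction in this assay cannot be ruled out. Compound 3 is expected to give 1500 nM, within 200 nM to 10000 nM. The expected step is a 3.2-fold lower number from compound 2 to compound 3 (0.50 log units; beyond the scatter).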

Compound 3, half-maximal effective concentration: 2830 nM
Beside the measured number, compound 3's estimate is 1.9-fold (0.28 log units) below it, within the range that was stated.
By their numbers in this assay, from the lowest: compound 1; then compounds 3 and 2 (each within the scatter of the next).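

In this assay the swap of 2-fluoroethyl for oxetan-3-yl on a saturated chain carbon bound to an aromatic nitrogen gives a 1.7-fold lower number from compound 2 to compound 3 (0.23 log units; within the scatter) and so separates these two groups by no more than repeat measurements would. The distance to compound 1 remains, at a 170-fold higher number from compound 1 to compound 3 (2.22 log units; beyond the scatter) for oxetan-3-yl in place of methyl, so the ring did not recover what the fluorinated chain had lost. Nothing available bears on the reason for this result. Going by these compounds, whether an amine or a carboxylic acid at this place would come closer to compound 1 stays open.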